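Fluoro in Place of Methoxy on a Shared Core

The compounds below may be only part of what the source reports. "The series", "measured", "known", "first", "only" and "open" are said of these compounds alone.

Compound 3 `C=CC(=O)Nc1cccc(Nc2ncnc(Nc3ccc(-c4ccc(OC)nc4)cc3)n2)c1` and compound 4 `C=CC(=O)Nc1cccc(Nc2ncnc(Nc3ccc(-c4ccc(F)nc4)cc3)n2)c1` share their core with compound 1 `C=CC(=O)N1CCc2ccc(Nc3ncnc(Nc4ccc(C(=O)N5CCCCC5)cc4)n3)cc21` and compound 2 `C=CC(=O)Nc1cccc(Nc2ncnc(Nc3ccc(C(=O)N4CCCCC4)cc3)n2)c1`. In a functional assay on Ramos cells (Homo sapiens) for antiproliferative activity, read by CCK-8 assay, with a stated time of 24 h (on this read-out lower numbers stand for stronger inhibition and higher numbers for weaker inhibition), compound 2 gives 6140 nM. In this assay compound 1 gives "not determined" (no result reported). In this assay compound 3 gives "not determined" (no result reported), so compound 3 stands without a value of its own, and the only anchor among these four compounds is compound 2. The change from compound 3 to compound 4 is fluoro in place of methoxy on an aromatic carbon. Among the compounds with values here, no step between two measured compounds is available here, so there is no basis for expecting a shift in this assay beyond the usual scatter, in either direction. With that caveat, compound 4 is estimated at 5000 nM in this assay, within a deliberately wide range from 800 nM to 30000 nM.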

Compound 4, half-maximal inhibitory concentration: 59200 nM
Beside the measured number, compound 4's estimate is 12-fold (1.07 log units) below it; the measured number lies above the stated range.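

In this assay, 6-fluoropyridin-3-yl in place of (piperidin-1-yl)carbonyl gives a 9.6-fold higher number from compound 2 to compound 4 (0.98 log units; beyond the scatter), which means weaker inhibition and shows that the group at this position matters for the result. Compound 3 has no value, so the step from methoxy to fluoro cannot be read. Nothing available explains the weaker result. The compounds shown leave open whether an amine in place of the fluoro would keep or restore inhibition. They also leave open how a simple (piperidin-1-yl)carbonyl replacement with a carboxylic acid would behave.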